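This account rests on a few compounds, and the source may have more. Where it says the series, first, only, none or still open, it means among the compounds named here.

The measured compounds so far:
compound 1, `CCCCC[C@@H](C(=O)NCNC(=O)c1ccc(-c2cc(OCC)cc(C(=O)O)c2)o1)[C@@H](CC)N(O)C=O`, < 1 nM
compound 2, `CCCCC[C@H](CN(O)C=O)C(=O)NCNC(=O)c1ccc(-c2cccc(OC)c2)o1`, 20 nM
compound 3, `CCCCC[C@H](CN(O)C=O)C(=O)NCNC(=O)c1ccc(-c2ccc(C(=O)O)cc2)o1`, 1 nM

All three were tested in an assay on CHO cells for inhibition of bone morphogenetic protein 1 (Homo sapiens), with stated times of 10 min and 60 min; a higher number here means a weaker inhibitor, a lower number a stronger inhibitor. For compound 1 this assay reports only a limit, < 1 nM; that is where compound 1 stands among the numbers shown (the limit of < 1 nM in this assay, at which 1 of the 3 values shown sits). Compound 2 gives 20 nM in this assay. Compound 3 gives 1 nM in this assay. Within the data shown here, the one measured step between compounds that differ in a single place is a 20-fold lower number from compound 2 to compound 3 (1.30 log units; beyond the scatter), a change at the same end of the shared core.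

Compound 4 is `CCCCC[C@@H](C(=O)NCNC(=O)c1ccc(-c2ccccc2)o1)[C@@H](CC)N(O)C=O`. It differs from compound 1 by a group of 6 heavy atoms (6 carbon; one six-membered aromatic ring of carbon only) in place of a group of 12 heavy atoms (9 carbon, 3 oxygen; one six-membered aromatic ring of carbon only), on an aromatic carbon. The substituted six-membered ring of compound 1, which carries a carboxylic acid, gives way to a bare phenyl. The step from compound 2 to compound 3 bears on this: there the arrival of a carboxylic acid on the same ring went with a large fall in the number, so its departure in compound 4 is expected to raise the number. Since compound 1 sits at a limit, the size of the step can only be guessed from that one measured step. Compound 4 is therefore expected to give a markedly higher number, an at least 8.0-fold higher number from compound 1 to compound 4 (0.90 log units; beyond the scatter), with an estimate for compound 4 of 8 nM, between 2 nM and 40 nM.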

Compound 4, half-maximal inhibitory concentration: 32 nM
Compound 4: middle estimate off by 4.0-fold (0.60 log units), on the low side; low and high end bracket the measured number.
By their numbers in this assay, from the lowest: compound 3; then compounds 2 and 4 (each within the scatter of the next).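

Stripping the substituted six-membered aromatic ring down to a bare phenyl, on the aromatic carbon next to the ring oxygen of the five-membered aromatic ring, gives an at least 32-fold higher number from compound 1 to compound 4 (1.50 log units; beyond the scatter) in this assay. Among these compounds, this is the first step at this position to be read on the chain that carries the ethyl branch, and it runs the same way as the step that brought in a carboxylic acid on the other chain, a 20-fold lower number from compound 2 to compound 3 (1.30 log units; beyond the scatter). The value of compound 1 is a limit and not a number, so the new step gives only a minimum size: the limit of < 1 nM in this assay, at which 1 of the 4 values shown sits.

Going by these compounds, what stays open is how much of this step belongs to the carboxylic acid and how much to the ethoxy group that leaves with it, and whether a phenyl carrying the carboxylic acid alone would stay close to compound 1. Also open, on these data alone, is whether an amine or a primary amide in place of the carboxylic acid on that ring would move the number in the same direction.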